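Swapping the aryl ketone of compound 2 for a methoxyphenyl

The source may report more compounds than this note shows. Statements on the series, on what has been measured and on what is new or still open speak of the compounds shown alone.

Two compounds of this series have been run in a functional assay on HOP-62 cells (Homo sapiens) for inhibition, read by sulforhodamine B assay, with a stated time of 48 h; on this read-out lower numbers stand for stronger inhibition of growth and higher numbers for weaker inhibition of growth. Compound 1 `COc1ccc(-c2cc(/C=C/C(=O)c3ccc(N)cc3)[nH]n2)cc1` gives 2800 nM. Compound 2 `COc1cc(-c2cc(/C=C/C(=O)c3ccc(Cl)c(Cl)c3)[nH]n2)cc(OC)c1OC` gives 1720 nM, the lower of the two numbers, although compound 1 sits within the usual scatter of it, so no order between the two can be claimed.

Compound 3 `COc1ccc(C(=O)/C=C/c2cc(-c3cc(OC)c(OC)c(OC)c3)n[nH]2)cc1` has not yet been measured. It differs from compound 2 in one place: 4-methoxyphenyl in place of 3,4-dichlorophenyl on a carbonyl carbon. Among the compounds with values here, no pair of measured compounds shows this exchange on its own, so nothing in the data fixes its size or direction in this assay. Within the data shown here, the only guide is that both measured compounds lie close together, which makes a change no larger than the scatter the most plausible outcome. Compound 3 is therefore expected to give roughly 3000 nM, within a range of 1000 nM to 9000 nM, an estimated step of a 1.7-fold higher number from compound 2 to compound 3 (0.24 log units; within the scatter) that would count as a slight weakening, if any.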

Compound 3, concentration for 50% growth inhibition: 1760 nM
Estimate against measurement, compound 3: 1.7-fold (0.23 log units) above; the measured number falls inside the stated range.
By their numbers in this assay, from the lowest: compounds 2, 3 and 1 (each within the scatter of the next).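

In this assay, 4-methoxyphenyl in place of 3,4-dichlorophenyl on a carbonyl carbon gives a 1.0-fold higher number from compound 2 to compound 3 (0.01 log units; within the scatter) and thus shows this exchange on its own, which compounds 1 and 2 could not do. At this place the read-out does not separate the two groups, although the entering group has a hydrogen-bond acceptor that the leaving group lacks and oxygen replaces both chlorine atoms. No measured evidence bears on this result.

On these data alone, it remains open whether a quite different group on this carbonyl carbon, such as a phenyl ring carrying a carboxylic acid or a longer alkyl chain, would move the number beyond the scatter. As far as these compounds go, it is also open whether the same exchange would read alike on the core of compound 1.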